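Ethylsulfanyl for Ethoxy: Expecting the Read-out of Compound 3

A few compounds are considered here, and "the series" means these few. Any claim that something is new, unique, unknown or untested is made for them only; others in the source may bear on it.

The two measured compounds share one core. Going by the values given here, compound 1 `[C-]#[N+]Cc1c(C)nc2c(OCc3ccccc3)cccn12` is the first of them, and in a functional assay on the whole organism with Rattus norvegicus as the target, with a stated time of 4 h, at a dose of 40 mg/kg by the intraperitoneal route (on this read-out higher numbers stand for more inhibition at the one dose given (going by the name of the read-out) and lower numbers for less inhibition), compound 1 gives 96%. Compound 2 `CCOCc1c(C)nc2c(OCc3ccccc3)cccn12` differs from it at the saturated chain carbon bound to an aromatic carbon, and in this assay compound 2 gives 84%. Among the compounds with values here, the only measured step is a number 12 percentage points lower from compound 1 to compound 2 (beyond the scatter), so of the two numbers known, compound 2 holds the lower one.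

Compound 3 `CCSCc1c(C)nc2c(OCc3ccccc3)cccn12` differs from compound 2 in a single place: ethylsulfanyl in place of ethoxy on a saturated chain carbon bound to an aromatic carbon. Within the data shown here, no measured step exchanges an oxygen-bearing chain for a sulfur-bearing one, so the sole guide is the step into compound 2, which shows that replacing the group on that saturated chain carbon shifted the read-out only modestly while it stayed high. On that basis the step of a number 2 percentage points lower from compound 2 to compound 3 (within the scatter) is expected to fall within or close to the scatter, with no firm direction. Compound 3 is therefore estimated at 82% in this assay, within a range from 62% to 96%.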

Compound 3, a percentage reported as inhibition, in the whole organism at one dose (the size of the read-out at that dose, not a potency): 36%
Compound 3: the middle estimate sits 46 percentage points above what was measured; the whole stated range lies above it.
By their numbers in this assay, from the lowest: compound 3; then compound 2; then compound 1.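

In this assay, ethylsulfanyl in place of ethoxy brings a number 48 percentage points lower from compound 2 to compound 3 (beyond the scatter), a large step at a place where the earlier change had brought only a number 12 percentage points lower from compound 1 to compound 2 (beyond the scatter). The position, a saturated chain carbon bound to an aromatic carbon, therefore does not treat all its groups alike: ethoxy and ethylsulfanyl match in their computed heavy-atom and hydrogen-bond counts and differ in oxygen against sulfur, yet the read-out separates them widely. The comparison with the group of compound 1 is wider still, at a number 60 percentage points lower from compound 1 to compound 3 (beyond the scatter), and compound 3 holds the lowest number of the three, with its steps to both others beyond the scatter. Nothing shown here offers any measurement that would account for this fall.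

The compounds shown leave open whether the fall holds for other sulfur-bearing chains, such as methylsulfanyl, the longer propylsulfanyl or ethylsulfonyl. They also leave open how, in this assay, an amine such as dimethylamino or a carboxylic acid would stand on that same saturated chain carbon.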